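The source may report more compounds than this note shows. Statements on the series, on what has been measured and on what is new or still open speak of the compounds shown alone.

Three compounds share one core. Going by the values given here, compound 1 `O=C(/C=C1\CCc2ccc(F)cc21)NCCO` gives 42% in a functional assay on the whole organism with Rattus norvegicus as the target, at a dose of 20 mg/kg by the oral route (a lower number here means less inhibition, a higher number more inhibition at the dose given (going by the name of the read-out)), the second highest of the three numbers known. Compound 2 `NC(=O)/C=C1\CCc2cc(F)ccc21` gives 54% in this assay, a number beyond the scatter above compound 1, while compound 3 `O=C(/C=C1\CCc2cc(F)c(F)cc21)NC1CC1` gives 30% in this assay, beyond the scatter below compound 1. Compound 4 `CCCNC(=O)/C=C1\CCc2ccc(F)cc21` has not been measured. It differs from compound 1 in one place: methyl in place of hydroxy on a saturated chain carbon, two bonds along the chain from an amide-type nitrogen. Among the compounds with values here, no measured pair shows this change, so the direction of the step rests on no comparison. Compound 4 is expected to give 40% in this assay, with a range from 20% to 60%. The expected step, a number 2 percentage points lower from compound 1 to compound 4 (within the scatter), is not one beyond the scatter.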

Compound 4, a percentage reported as inhibition, in the whole organism at one dose (the size of the read-out at that dose, not a potency): 0%
The estimate for compound 4 lay 40 percentage points above the measured number, and the stated range ends above it.
By their numbers in this assay, from the lowest: compound 4; then compound 3; then compound 1; then compound 2.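

Methyl in place of hydroxy on a saturated chain carbon, two bonds along the chain from an amide-type nitrogen, is the only single-place change shown in this assay, and it gives a number 42 percentage points lower from compound 1 to compound 4 (beyond the scatter). The read-out at this dose therefore depends strongly on what the chain carries at this place, with 2-hydroxyethyl in compound 1 and propyl in compound 4. No measurement shown bears on why the step is so large. Going by these compounds, whether an amine, a methoxy group or a carboxylic acid at this place would retain the read-out remains open. So does whether the same change would give a similar step on the cores of compound 2 and compound 3.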